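A few compounds are considered here, and "the series" means these few. Any claim that something is new, unique, unknown or untested is made for them only; others in the source may bear on it.

Two compounds have been measured so far in a functional assay on MCF7 cells (Homo sapiens) for inhibition, read by MTT assay, with a stated time of 48 h (on this read-out higher numbers stand for weaker inhibition and lower numbers for stronger inhibition), and they are:

- compound 1 `COc1ccc(-c2nnnn2-c2cc(OC)c(OC)c(OC)c2)c(O)c1O` with 6600 nM
- compound 2 `COc1ccc(-c2nnnn2-c2cc(OC)c(OC)c(OC)c2)c(O)c1` with 8200 nM

Among the measured compounds shown here, compound 2 lies within the usual scatter of compound 1, its only point of comparison, so the two cannot be ranked.

The next compound is compound 3 `COc1ccc(-c2nnnn2-c2cc(OC)c(OC)c(OC)c2)c(O)c1N` and it differs from compound 2 by one change amino in place of hydrogen on an aromatic carbon in which amino takes the place of hydrogen on an aromatic carbon, ortho to a hydroxy group and ortho to a methoxy group.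

For the measured compounds named here, the one measured step at that same carbon is a 1.2-fold higher number from compound 1 to compound 2 (0.09 log units; within the scatter) and it exchanges hydroxy for hydrogen without leaving the scatter. No amino group has been measured on this core, so one small step is thin evidence. Even so, it gives no reason to expect a large shift in this assay in either direction.

The expected change is therefore small, an estimated 1.2-fold lower number from compound 2 to compound 3 (0.07 log units; within the scatter) that stays within the scatter. For compound 3 the estimate is 7000 nM and the expected range runs from 2500 nM up to 20000 nM as a wide allowance for an untested group.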

Compound 3, half-maximal inhibitory concentration: 2900 nM
Compound 3: the middle estimate sits 2.4-fold (0.38 log units) above what was measured; the range from low to high includes it.
By their numbers in this assay, from the lowest: compound 3; then compounds 1 and 2 (each within the scatter of the next).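

In this assay, this carbon, ortho to a hydroxy group and ortho to a methoxy group, turns out to be sensitive to what it carries: putting amino in place of hydrogen gives a step beyond the scatter (a 2.8-fold lower number from compound 2 to compound 3 (0.45 log units; beyond the scatter)), though a modest one, and the first such step among these compounds. Amino also separates from hydroxy at the same carbon (a 2.3-fold lower number from compound 1 to compound 3 (0.36 log units; beyond the scatter)), whereas hydroxy and hydrogen could not be told apart, so among the three groups compared here, only amino moves the number beyond the scatter. Nothing in the available data explains why amino behaves differently from the other two groups.

As far as these compounds go, what remains open is whether this step is tied to the plain amino group or also holds for related nitrogen groups such as methylamino, dimethylamino or acetamido. A halogen such as fluorine or chlorine on the same carbon, or a carboxylic acid there, would also show whether amino stands apart from a wider range of groups or is only one of several that shift the number.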